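Swapping a Pentyl Chain for Methoxy

A few compounds are considered here, and "the series" means these few. Any claim that something is new, unique, unknown or untested is made for them only; others in the source may bear on it.

In a functional assay on MCF7 cells (Homo sapiens) for inhibition, read by MTT assay, with a stated time of 72 h (on this read-out lower numbers stand for stronger inhibition and higher numbers for weaker inhibition), compound 1 `CCCc1ccc(NC(=O)C2CCN(C/C=C/c3ccccc3)CC2)cc1` gives 9030 nM and compound 2 `CCCCCc1ccc(NC(=O)C2CCN(C/C=C/c3ccccc3)CC2)cc1` gives 3740 nM, the lower of these two numbers. Compound 3 `COc1ccc(NC(=O)C2CCN(C/C=C/c3ccccc3)CC2)cc1` differs from compound 2 as follows: methoxy in place of pentyl on an aromatic carbon. Within the data shown here, only one measured step bears on this change, the modest 2.4-fold lower number from compound 1 to compound 2 (0.38 log units; beyond the scatter), where ethyl took the place of hydrogen on a saturated chain carbon. Losing the pentyl chain should therefore move the number the opposite way, upward, by a similar or somewhat larger amount. The expected change is a 2.9-fold higher number from compound 2 to compound 3 (0.47 log units; beyond the scatter) in this assay. The estimated value for compound 3 is 11000 nM, with an expected range from 4500 nM to 27000 nM.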

Compound 3, half-maximal inhibitory concentration: > 100000 nM
Compound 3: only a limit was reported (the forecaster's own chance of this, stated with the estimate: 15%); middle value at least 9.0-fold (0.95 log units) from the limit.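

For compound 3, this assay gives only a limit, not a number: the limit of > 100000 nM in this assay, at which 1 of the 3 values shown sits.

Even so, methoxy in place of pentyl gives an at least 26-fold higher number from compound 2 to compound 3 (1.42 log units; beyond the scatter), and methoxy in place of propyl gives an at least 11-fold higher number from compound 1 to compound 3 (1.04 log units; beyond the scatter). Both steps dwarf the earlier one between the two chains, so the group on this aromatic carbon matters far more than that step suggested.

Still open, from the compounds shown here alone, is whether the loss of the chain or the arrival of the oxygen accounts for the jump. Ethoxy, or a plain ethyl chain, on this same carbon would help tell these apart.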